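The compounds below may be only part of what the source reports. "The series", "measured", "known", "first", "only" and "open" are said of these compounds alone.

Working notes on the series. All three measured compounds share one core and differ only in the aryl group on a saturated chain carbon bound to an amine nitrogen in a ring. Compound 1 `COc1ccc2[nH]c3c(c2c1)CCNC31CCN(Cc2c(F)ccc(Cl)c2F)CC1` gives 1500 nM in an assay on FRT cells for positive allosteric modulation of Cystic fibrosis transmembrane conductance regulator variant N1303K (Homo sapiens), in the presence of a further agent that is not named here; a higher number here means that more compound is needed for the effect, a lower number that less compound is needed. Compound 2 `COc1ccc2[nH]c3c(c2c1)CCNC31CCN(Cc2ccccc2Cl)CC1` gives 2200 nM and compound 3 `COc1ccc2[nH]c3c(c2c1)CCNC31CCN(Cc2ccc(Br)cc2F)CC1` gives 1600 nM. Compound 1 sits at one edge of a narrow spread: a 1.1-fold higher number from compound 1 to compound 3 (0.03 log units; within the scatter) and a 1.5-fold higher number from compound 1 to compound 2 (0.17 log units; within the scatter), both within the scatter, as is a 1.4-fold lower number from compound 2 to compound 3 (0.14 log units; within the scatter). Every swap among these halogenated phenyl groups thus leaves the number unchanged within the scatter.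

Compound 4 `COc1ccc2[nH]c3c(c2c1)CCNC31CCN(Cc2ccco2)CC1` is not yet measured. The change from compound 1 is furan-2-yl in place of 3-chloro-2,6-difluorophenyl on a saturated chain carbon bound to an amine nitrogen in a ring. Among the measured compounds shown here, no measured step replaces a phenyl with a five-membered aromatic ring with a hetero atom, so the three steps bear on it only as a sign that the aryl group has so far tolerated variation without effect beyond the scatter. The expectation for compound 4 is therefore a 1.7-fold higher number from compound 1 to compound 4 (0.22 log units; within the scatter), with a wider range than the scatter to reflect the untested ring type, and the estimated value is 2500 nM between 900 nM and 8000 nM.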

Compound 4, half-maximal effective concentration: 16400 nM
Estimate against measurement, compound 4: 6.6-fold (0.82 log units) below; measured number above the stated range.
By their numbers in this assay, from the lowest: compounds 1, 3 and 2 (each within the scatter of the next); then compound 4.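

In this assay, furan-2-yl on a saturated chain carbon bound to an amine nitrogen in a ring gives an 11-fold higher number from compound 1 to compound 4 (1.04 log units; beyond the scatter) and a 10-fold higher number from compound 3 to compound 4 (1.01 log units; beyond the scatter) and also a 7.5-fold higher number from compound 2 to compound 4 (0.87 log units; beyond the scatter), all beyond the scatter. This place is therefore sensitive to the aryl group, and the tolerance seen earlier holds only among the three halogenated phenyl groups, not for this five-membered aromatic ring with 1 hetero atom. No measurement shown bears on why the number rises with this change.

The compounds shown leave open whether the rise follows the smaller ring, the ring oxygen or the loss of the halogens, since all of these change together in compound 4. Unsubstituted phenyl and thiophen-2-yl at the same place would separate these differences.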